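This account rests on a few compounds, and the source may have more. Where it says the series, first, only, none or still open, it means among the compounds named here.

Measured so far, in a physicochemical assay for lipophilicity; on this read-out higher numbers stand for higher lipophilicity and lower numbers for lower lipophilicity: compound 1 `C[n+]1ccn(COCCCCS(C)(=O)=O)c1/C=N/O` gives -3.11; compound 2 `CC(OCn1cc[n+](C)c1/C=N/O)C(C)(C)[N+](=O)[O-]` gives -1.75.

Compound 2 stands highest of the two numbers in this assay; its nearest neighbour is compound 1, which sits beyond the scatter below it. Compound 3 `CC(CS(C)(=O)=O)OCn1cc[n+](C)c1/C=N/O` awaits measurement. It differs from compound 2 in one place: (methylsulfonyl)methyl in place of 1-methyl-1-nitroethyl on a saturated chain carbon bound to an oxygen on a saturated carbon and a saturated chain carbon. Among the measured compounds shown here, no step between measured compounds covers this change, so its size is not known from the series. Compound 1 also carries a methylsulfonyl group and gives -3.11. On that basis the step is expected to run downward beyond the scatter, a number 1.05 log units lower from compound 2 to compound 3 (beyond the scatter). Compound 3 is estimated at -2.8, within -3.5 to -2.1.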

Compound 3, distribution coefficient: -2.66
Beside the measured number, compound 3's estimate is 0.14 log units below it; the range from low to high includes it.
By their numbers in this assay, from the lowest: compound 1; then compound 3; then compound 2.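

In this assay, the series now has its first step at this position, a number 0.91 log units lower from compound 2 to compound 3 (beyond the scatter), with (methylsulfonyl)methyl in place of 1-methyl-1-nitroethyl. The number shifts beyond the scatter even though both groups show the same counts of hydrogen-bond donors and acceptors, so those counts alone do not separate this pair. No supporting measurement bears on the reason for the step.

On these data alone, with a single pair at this position, the step's size on any other scaffold remains unknown. As far as these compounds go, it also remains open where an amine or a carboxylic acid on this saturated chain carbon would fall relative to compound 2 and compound 3.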